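Sulfonyl replaces cinnamoyl on the terminal piperazine nitrogen

The source may hold more compounds than are shown below. What is called first, only, known or untested is meant among the compounds shown, and "the series" means these compounds.

Measured so far:
Compound 1 `CCN(CC)c1ccc2cc(C(=O)c3ccc(N4CCN(C(=O)CN5CCN(C(=O)CCl)CC5)CC4)cc3)oc2c1`: 20900 nM
Compound 2 `CCN(CC)c1ccc2cc(C(=O)c3ccc(N4CCN(C(=O)CN5CCN(C(=O)/C=C/c6ccccc6)CC5)CC4)cc3)oc2c1`: > 100000 nM
Compound 3 `CCN(CC)c1ccc2cc(C(=O)c3ccc(N4CCN(C(=O)CN5CCN(S(=O)(=O)c6ccc(OC(F)(F)F)cc6)CC5)CC4)cc3)oc2c1`: 34700 nM

In an ADME assay on L02 cells (Homo sapiens) for cytotoxicity, read by MTT assay, with a stated time of 48 h (on this read-out lower numbers stand for stronger inhibition and higher numbers for weaker inhibition), compound 2 stands at a limit of the assay, > 100000 nM, and no number is known for it. In this assay compound 1 gives 20900 nM. Compound 3 carries a sulfonyl on the same ring nitrogen as compound 4. Compound 3 gives 34700 nM.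

Compound 4 `CCN(CC)c1ccc2cc(C(=O)c3ccc(N4CCN(C(=O)CN5CCN(S(=O)(=O)c6ccc(C#N)cc6)CC5)CC4)cc3)oc2c1` has not been measured. It differs from compound 2 by (4-cyanophenyl)sulfonyl in place of (2-phenylethenyl)carbonyl on an amine nitrogen in a ring.

Among the measured compounds shown here, the only measured step that touches this nitrogen is an at least 4.7-fold higher number from compound 1 to compound 2 (0.67 log units; beyond the scatter). Compound 2 sits at the upper limit of the assay (the limit of > 100000 nM in this assay, at which 1 of the 3 values shown sits), so that step is a lower bound only. Compound 3 shows that a sulfonyl at this position can return a measurable number; compound 4 is expected to do the same, with a step of an at least 2.5-fold lower number from compound 2 to compound 4 (0.39 log units; beyond the scatter) that is an estimate only. Compound 4 is therefore expected near 40000 nM, within 15000 nM to 100000 nM.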

Compound 4, half-maximal inhibitory concentration: 44100 nM
Estimate against measurement, compound 4: 1.1-fold (0.04 log units) below; the range from low to high includes it.
By their numbers in this assay, from the lowest: compounds 1, 3 and 4 (each within the scatter of the next, the first and the last beyond it). At a limit, above all of these: compound 2.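

In this assay compound 2 stands at a limit, which is not a number: the limit of > 100000 nM in this assay, at which 1 of the 4 values shown sits. As far as these compounds go, the (4-cyanophenyl)sulfonyl group in place of (2-phenylethenyl)carbonyl on the amine nitrogen in a ring gives a measurable value (an at least 2.2-fold lower number from compound 2 to compound 4 (0.35 log units; beyond the scatter)), and the true size of this step stays unknown, with only its lower bound printed. A measurable value at this nitrogen now holds for two sulfonyl compounds, with cyano and trifluoromethoxy on the aromatic carbon not separated (a 1.3-fold higher number from compound 3 to compound 4 (0.10 log units; within the scatter)), while compound 4 stands modestly apart from the (chloromethyl)carbonyl compound (a 2.1-fold higher number from compound 1 to compound 4 (0.32 log units; beyond the scatter)).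

Still open, from the compounds shown here alone, is whether the same range holds with an amine or a carboxylic acid on the aromatic ring of the sulfonyl group. A methylsulfonyl group, with no aromatic ring, is also untested in the compounds shown here.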